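Ring Size on the Triazole Nitrogen: From Isobutyl to Cycloheptyl

The compounds below may be only part of what the source reports. "The series", "measured", "known", "first", "only" and "open" are said of these compounds alone.

Compound 1 `CC(C)Cn1nc(C(=O)N[C@H]2COc3ccccc3N(C)C2=S)nc1Cc1ccccc1` gives 1230 nM in a functional assay on HT-29 cells (Homo sapiens) for inhibition, read by luminescence and CellTiter-Glo, with a stated time of 24 h; on this read-out lower numbers stand for an effect already at smaller amounts and higher numbers for an effect only at larger amounts of compound.
Compound 2 `CN1C(=S)[C@@H](NC(=O)c2nc(Cc3ccccc3)n(C3CCC3)n2)COc2ccccc21` gives 181 nM in this assay.

Among the two compounds measured so far, compound 1 stands with the highest number; its nearest neighbour is compound 2, and the step of a 6.8-fold lower number from compound 1 to compound 2 (0.83 log units; beyond the scatter) shows that replacing the isobutyl with a cyclobutyl on the aromatic nitrogen brought a clearly smaller number, beyond the usual scatter.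

Compound 3 `CN1C(=S)[C@@H](NC(=O)c2nc(Cc3ccccc3)n(C3CCCCCC3)n2)COc2ccccc21` has not yet been measured. It differs from compound 1 as follows: cycloheptyl in place of isobutyl on an aromatic nitrogen. For the measured compounds named here, the only measured step that bears on this change is the one from compound 1 to compound 2, where a ring on the same aromatic nitrogen replaced the isobutyl; cycloheptyl is also a ring in that place, though a larger one, so no measured pair tells how far the benefit carries to a seven-membered ring. The step from compound 1 to compound 3 is therefore expected to be a 3.1-fold lower number from compound 1 to compound 3 (0.49 log units; beyond the scatter), toward a lower number. On that basis, compound 3 is estimated at 400 nM in this assay, with a range from 120 nM to 1400 nM.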

Compound 3, half-maximal effective concentration: 5530 nM
Compound 3: middle estimate off by 14-fold (1.14 log units), on the low side; measured number above the stated range.
By their numbers in this assay, from the lowest: compound 2; then compound 1; then compound 3.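

In this assay a ring on this aromatic nitrogen does not lower the number by itself: cycloheptyl in place of isobutyl gives a 4.5-fold higher number from compound 1 to compound 3 (0.65 log units; beyond the scatter) and so runs opposite to the earlier change to cyclobutyl. Ring size therefore matters at this position, as the change between the two ring compounds alone gives a 31-fold higher number from compound 2 to compound 3 (1.49 log units; beyond the scatter) and is the largest step among the three compounds. The open-chain isobutyl of compound 1 lies between the two ring compounds, so among these three the number does not simply follow the presence of a ring or the count of heavy atoms, and no measurement at hand explains why the seven-membered ring does so much worse than cyclobutyl.

The three compounds leave open how the number changes between the four-membered and seven-membered rings, and whether it climbs gradually or jumps at one size, which cyclopentyl and cyclohexyl would help to settle. They also leave open whether cyclopropyl would give a lower number than cyclobutyl, and how a ring holding an oxygen or a nitrogen, such as tetrahydropyranyl or piperidinyl, would behave at this position.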